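A few compounds are considered here, and "the series" means these few. Any claim that something is new, unique, unknown or untested is made for them only; others in the source may bear on it.

In a functional assay on PANC-1 cells (Homo sapiens) for inhibition, read by MTT assay, with a stated time of 24 h, tested at 10 uM (a higher number here means more inhibition at the concentration tested (going by the name of the read-out), a lower number less inhibition), the three measured compounds give the following numbers:

compound 1 `COc1ccccc1NC(=O)Oc1cc(=O)n(CCCO)c2c1CC(C/C=C(\C)CCC=C(C)C)C(C)(C)C2` gives 53%
compound 2 `CC(C)=CCC/C(C)=C/CC1Cc2c(OC(=O)Nc3cccc(F)c3)cc(=O)n(CCCO)c2CC1(C)C` gives 52.3%
compound 3 `CC(C)=CCC/C(C)=C/CC1Cc2c(OC(=O)Nc3ccc(F)c(F)c3)cc(=O)n(CCCO)c2CC1(C)C` gives 43.7%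

Compound 3 is the starting point. Its number is separated from compound 2 by a number 8.6 percentage points lower from compound 2 to compound 3 (within the scatter) and from compound 1 by a number 9.3 percentage points lower from compound 1 to compound 3 (within the scatter), so within this set of three the compounds cannot be told apart in this assay.

Compound 4 `CC(C)=CCC/C(C)=C/CC1Cc2c(OC(=O)Nc3cccc(C(F)(F)F)c3)cc(=O)n(CCCO)c2CC1(C)C` has not yet been measured. It differs from compound 3 in one place: 3-(trifluoromethyl)phenyl in place of 3,4-difluorophenyl on an amide-type nitrogen.

Two earlier steps bear on this change, each an exchange of the aryl group on the same amide-type nitrogen. The exchange from compound 1 to compound 2 gave a number 0.7 percentage points lower from compound 1 to compound 2 (within the scatter), and from compound 1 to compound 3 gave a number 9.3 percentage points lower from compound 1 to compound 3 (within the scatter). The fluoro added from compound 2 to compound 3 gave a number 8.6 percentage points lower from compound 2 to compound 3 (within the scatter). None of these moved the number beyond the scatter, so an exchange of the aryl group for 3-(trifluoromethyl)phenyl is expected to behave the same way, with no step beyond the scatter in either direction.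

Compound 4 is therefore estimated at 48%, with a range from 35% to 61% in this assay. The expected step is a number 4.3 percentage points higher from compound 3 to compound 4 (within the scatter).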

Compound 4, a percentage reported as inhibition, at one concentration (the size of the read-out at that concentration, not a potency): 44%
Estimate against measurement, compound 4: 4 percentage points above; the measured number falls inside the stated range.
By their numbers in this assay, from the lowest: compounds 3, 4, 2 and 1 (each within the scatter of the next).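

In this assay, 3-(trifluoromethyl)phenyl in place of 3,4-difluorophenyl on the amide-type nitrogen gives a number 0.3 percentage points higher from compound 3 to compound 4 (within the scatter) and the comparisons with the other two aryl groups give a number 8.3 percentage points lower from compound 2 to compound 4 (within the scatter) and a number 9 percentage points lower from compound 1 to compound 4 (within the scatter) for the same compound. The position therefore takes an entering group of 10 heavy atoms in place of one of 8, and trifluoromethyl in place of fluoro, with no step beyond the scatter, so 2-methoxyphenyl, 3-fluorophenyl, 3,4-difluorophenyl and 3-(trifluoromethyl)phenyl all remain within the scatter of one another at this one concentration. Nothing measured here offers an explanation for this flat picture at the position.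

Still open, from the compounds shown here alone, is whether any group on this nitrogen can move the number beyond the scatter, for instance a phenyl ring carrying an amine or a carboxylic acid, or a plain alkyl chain in place of the aryl ring. Going by these compounds, all four compounds share the same core and give a read-out at a single concentration, so whether they differ in potency also stays open.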